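Moving the Chlorine Around the Amide Ring

The source may report more compounds than this note shows. Statements on the series, on what has been measured and on what is new or still open speak of the compounds shown alone.

Three compounds share one core and differ only in the ring on the carbonyl carbon of the amide. Compound 1 `CCCCCCCCCCCCn1nnc(C(NC(=O)c2c(C)cccc2C)c2ccccc2)n1` gives 310 nM in an assay on microsomes from liver for inhibition of sterol O-acyltransferase 1 (Rattus norvegicus); a lower number here means a stronger inhibitor, a higher number a weaker inhibitor. Compound 2 `CCCCCCCCCCCCn1nnc(C(NC(=O)c2ccc(Cl)cc2)c2ccccc2)n1` gives 440 nM, and compound 3 `CCCCCCCCCCCCn1nnc(C(NC(=O)c2ccc(OC)cc2)c2ccccc2)n1` gives 600 nM. Among the measured compounds shown here, the steps of a 1.4-fold higher number from compound 1 to compound 2 (0.15 log units; within the scatter) and a 1.9-fold higher number from compound 1 to compound 3 (0.29 log units; within the scatter) lie within the scatter, as does a 1.4-fold higher number from compound 2 to compound 3 (0.13 log units; within the scatter), so no compound stands apart from the others beyond the scatter; compound 3 merely sits at the upper end of a narrow spread.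

Compound 4 `CCCCCCCCCCCCn1nnc(C(NC(=O)c2cccc(Cl)c2)c2ccccc2)n1` has not been measured. Its change from compound 3 is 3-chlorophenyl in place of 4-methoxyphenyl on a carbonyl carbon. The step of a 1.4-fold higher number from compound 2 to compound 3 (0.13 log units; within the scatter) shows that swapping methoxy for chloro on the aromatic ring changed little, and compound 2 already carries a chlorine on that ring. For the measured compounds named here, a shift of the chlorine to another position has no measured counterpart here. The expected step of a 1.3-fold lower number from compound 3 to compound 4 (0.12 log units; within the scatter) is therefore small, at most a slight fall in the number. Compound 4 is estimated at 450 nM, with a range from 200 nM to 1000 nM.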

Compound 4, half-maximal inhibitory concentration: 250 nM
Compound 4: the middle estimate sits 1.8-fold (0.26 log units) above what was measured; low and high end bracket the measured number.
By their numbers in this assay, from the lowest: compounds 4, 1, 2 and 3 (each within the scatter of the next, the first and the last beyond it).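

Among the compounds shown here, the step of a 2.4-fold lower number from compound 3 to compound 4 (0.38 log units; beyond the scatter) in this assay is the first here to pass beyond the scatter, so the group on this carbonyl carbon can shift the number, though only modestly. Placing 3-chlorophenyl in place of 4-chlorophenyl gives a 1.8-fold lower number from compound 2 to compound 4 (0.25 log units; within the scatter) and placing it in place of 2,6-dimethylphenyl gives a 1.2-fold lower number from compound 1 to compound 4 (0.09 log units; within the scatter) and both steps stay within the scatter, so compound 4 does not stand apart from either of those compounds and any effect of moving the chlorine remains unresolved. Nothing available explains the difference between the 4-methoxyphenyl and 3-chlorophenyl compounds.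

From the compounds shown here alone, how a ring carrying a nitrile, an amine or a carboxylic acid would behave on this carbonyl carbon remains open. So does the effect of a shorter chain on the shared core.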